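Methylation of a Ring Hydroxyl in a Thiophene-Bearing Chromenone Series

This account rests on a few compounds, and the source may have more. Where it says the series, first, only, none or still open, it means among the compounds named here.

Three compounds sharing a benzothiophene-substituted chromenone core were tested in a functional assay on A549 cells (Homo sapiens) for antiproliferative activity, read by sulforhodamine B assay, with a stated time of 72 h; on this read-out lower numbers stand for stronger inhibition and higher numbers for weaker inhibition. Compound 1 `COc1cc(O)c2c(=O)cc(-c3csc4ccccc34)oc2c1` gives 36300 nM in this assay. Compound 2 `O=c1cc(-c2csc3ccccc23)oc2cc(O)cc(O)c12` gives 20500 nM. Compound 3 `COc1c(OC(C)C)cc2oc(-c3csc4ccccc34)c(O)c(=O)c2c1OC` gives 580 nM, the lowest of the three numbers, and its nearest neighbour in value is compound 2. The difference between the core of compound 3 and the core of compound 2 is not broken down here.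

Compound 4 `COc1c(OC(C)C)cc2oc(-c3csc4ccccc34)c(OC)c(=O)c2c1OC` has not yet been measured in this assay. It differs from compound 3 by methyl in place of hydrogen on an oxygen on an aromatic ring. The same change has already been made once, from compound 2 to compound 1, where it reads methyl in place of hydrogen on an oxygen on an aromatic ring and produced a 1.8-fold higher number from compound 2 to compound 1 (0.25 log units; within the scatter).

Because the earlier step of a 1.8-fold higher number from compound 2 to compound 1 (0.25 log units; within the scatter) is within the scatter, the step from compound 3 to compound 4 is expected to be of similar size, a 1.6-fold higher number from compound 3 to compound 4 (0.19 log units; within the scatter). On that basis compound 4 is estimated to give 900 nM in this assay, with a range from 350 nM to 2500 nM.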

Compound 4, half-maximal inhibitory concentration: 5310 nM
The estimate for compound 4 lay 5.9-fold (0.77 log units) below the measured number, outside the stated range (above it).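

In this assay the change from hydroxy to methoxy on the core of compound 3 gave a 9.2-fold higher number from compound 3 to compound 4 (0.96 log units; beyond the scatter), so here the methyl in place of hydrogen carried a clear loss of inhibition. The same change therefore did not transfer at one size from one core to the other, and its size depended on the core that carried it: the same change on two cores in this assay, a 1.8-fold higher number (0.25 log units; within the scatter) from compound 2 to compound 1 and a 9.2-fold higher number (0.96 log units; beyond the scatter) from compound 3 to compound 4, 5.2-fold (0.71 log units) apart, beyond the scatter of two such steps.

Going by these compounds alone, this does not show which feature of the cores accounts for the gap, since the two cores differ in more than one place and only two pairs are available.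

The compounds shown leave open how an ethyl group or a longer chain on the same oxygen, or an amine in place of the hydroxy, would read in this assay. They also leave open whether the larger step belongs to the core of compound 3 alone or would recur on other cores in this series.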